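Estimating Growth Inhibition for Compound 3

A few compounds are considered here, and "the series" means these few. Any claim that something is new, unique, unknown or untested is made for them only; others in the source may bear on it.

Measured compounds:
compound 1 `COc1cc(OC)n2s/c(=N\C(=O)c3c(-c4ccc(Cl)cc4Cl)noc3C)nc2n1`: 85.6%
compound 2 `Cc1cc(Cl)nc(NC(=S)NC(=O)c2c(-c3ccc(Cl)cc3Cl)noc2C)n1`: 48.7%

In a functional assay on the whole organism (strain L.) for inhibition, with Echinochloa crus-galli as the target, with a stated time of 72 h, tested at 100 mg/L (a higher number here means more inhibition of growth at the concentration tested, a lower number less inhibition of growth), compound 2 gives 48.7%, the lower of the two numbers, and compound 1 gives 85.6%. The gap between the two lies beyond the scatter. Compound 3 `COc1cc(OC)nc(NC(=S)NC(=O)c2c(-c3ccc(Cl)cc3Cl)noc2C)n1` differs from compound 2 in one place: 4,6-dimethoxypyrimidin-2-yl in place of 4-chloro-6-methylpyrimidin-2-yl on an amide-type nitrogen. Going by the values given here, no measured pair shows this change on the shared core, so the step size is uncertain. A moderate rise in this assay is expected because compound 1, carrying the same 4,6-dimethoxypyrimidin-2-yl group on a different core, gives 85.6%. Compound 3 is estimated at 65%, within 40% to 88%. The expected step is a number 16.3 percentage points higher from compound 2 to compound 3 (beyond the scatter) in this assay.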

Compound 3, percent growth inhibition at one concentration: 60.9%
Compound 3: middle estimate off by 4.1 percentage points, on the high side; the range from low to high includes it.
By their numbers in this assay, from the lowest: compound 2; then compound 3; then compound 1.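

In this assay, the change on the amide-type nitrogen from 4-chloro-6-methylpyrimidin-2-yl to 4,6-dimethoxypyrimidin-2-yl gives a number 12.2 percentage points higher from compound 2 to compound 3 (beyond the scatter) on the shared core. Going by these compounds alone, this is the first direct pair, and it shows that the group at this place can shift growth inhibition measurably. Nothing measured here explains the shift.

From the compounds shown here alone, the chlorine and the methyl leave together, so their separate shares stay unknown. Going by these compounds, how a 4,6-dimethylpyrimidin-2-yl group or a plain phenyl ring would behave on this nitrogen also remains open.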